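A few compounds are considered here, and "the series" means these few. Any claim that something is new, unique, unknown or untested is made for them only; others in the source may bear on it.

Compound 1 `O=C(Nc1ccc(-n2ccc3c(NC(=O)c4ccccc4)ncnc32)cc1)c1ccc(Cl)c(Cl)c1`: 5000 nM in an ADME assay on HS27 cells (Homo sapiens) for antiproliferative activity, read by MTT assay, with a stated time of 24 h; on this read-out higher numbers stand for weaker inhibition and lower numbers for stronger inhibition.
Compound 2 `O=C(Nc1ccc(-n2ccc3c(NC(=O)c4ccccc4)ncnc32)cc1)Nc1cc(C(F)(F)F)cc(C(F)(F)F)c1`: in this assay compound 2 reaches only a limit, > 10000 nM.

In this assay, going by the values given here, compound 1 gives the only numerical value among the measured pair; the other entry is a limit of the assay. Compound 2 sits at the limit of > 10000 nM in this assay, at which 1 of the 2 values shown sits. Compound 3 `O=C(Nc1ccc(-n2ccc3c(NC(=O)c4ccccc4)ncnc32)cc1)Nc1ccc(Cl)c(Cl)c1` shares the core of compound 1 and differs from it in one place, ((3,4-dichlorophenyl)amino in place of 3,4-dichlorophenyl on a carbonyl carbon), so that the amide linkage of compound 1 becomes the carbamoyl linkage found in compound 2. Among the compounds with values here, the two measured compounds give no directly comparable step, so the size of the change is an expectation only. Compound 3 is expected to lose ground or at most hold level, because compound 2, which carries the same carbamoyl linkage, sits at the limit of > 10000 nM in this assay, at which 1 of the 2 values shown sits. The step from compound 1 is estimated as a 1.6-fold higher number from compound 1 to compound 3 (0.20 log units; within the scatter). Compound 3 is estimated at 8000 nM, within a range from 3000 nM to 20000 nM.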

Compound 3, half-maximal inhibitory concentration: 4500 nM
Compound 3: the middle estimate sits 1.8-fold (0.25 log units) above what was measured; the range from low to high includes it.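

In this assay, placing (3,4-dichlorophenyl)amino in place of 3,4-dichlorophenyl on a carbonyl carbon gives a 1.1-fold lower number from compound 1 to compound 3 (0.05 log units; within the scatter), so the amide linkage and the carbamoyl linkage cannot be told apart with this pair. Until now the carbamoyl linkage had appeared only in compound 2, and compound 3 shows that a compound with this linkage can give a measured number in this assay. Compound 2, with its bis(trifluoromethyl)phenyl group, remains a limit and not a number: the limit of > 10000 nM in this assay, at which 1 of the 3 values shown sits.

From the compounds shown here alone, it remains open how a benzylamino group or a morpholine on the same carbonyl carbon would read in this assay. Going by these compounds, it is also open how far compound 2 really lies from compound 3, as a limit gives no size for that difference.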